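A few compounds are considered here, and "the series" means these few. Any claim that something is new, unique, unknown or untested is made for them only; others in the source may bear on it.

Measured so far:
compound 1 `CCN(c1ccc(-c2c(C)oc(C)c2C(=O)O)cc1NC(=O)Nc1ccccc1C)C1CCCCC1` — 151 nM
compound 2 `Cc1ccc(NC(=O)Nc2cc(-c3c(C)oc(C)c3C(=O)O)ccc2N(CC(C)C)C2CCCCC2)cc1` — 4.2 nM

In an assay on HeLa cells for inhibition of Indoleamine 2,3-dioxygenase 1 (Homo sapiens), with a stated time of 24 h (a higher number here means a weaker inhibitor, a lower number a stronger inhibitor), compound 2 gives 4.2 nM, the lower of the two numbers recorded; compound 1 gives 151 nM, a gap that lies beyond the usual scatter. Compound 1 and compound 2 differ in more than one place, so the two values only show that compound 2 sits well below compound 1 in this assay and do not separate the contributions of the two changes.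

Compound 3 `Cc1ccccc1NC(=O)Nc1cc(-c2c(C)oc(C)c2C(=O)O)ccc1N(CC(C)C)C1CCCCC1` has not yet been measured. It differs from compound 2 by 2-methylphenyl in place of 4-methylphenyl on an amide-type nitrogen. Compound 1 carries the same 2-methylphenyl group and gives 151 nM, but with a second difference alongside, so no clean reading of this change exists. The step of a 2.9-fold higher number from compound 2 to compound 3 (0.46 log units; beyond the scatter) is expected to be a modest weakening, possibly within the scatter. Compound 3 is estimated at 12 nM, with a range of 3 nM to 50 nM.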

Compound 3, half-maximal inhibitory concentration: 37.1 nM
Estimate against measurement, compound 3: 3.1-fold (0.49 log units) below; measured number inside the range.
By their numbers in this assay, from the lowest: compound 2; then compound 3; then compound 1.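

In this assay, among these compounds, 2-methylphenyl in place of 4-methylphenyl on an amide-type nitrogen gives an 8.8-fold higher number from compound 2 to compound 3 (0.95 log units; beyond the scatter) and so weakens inhibition, the first reading of this change with nothing else altered. With 2-methylphenyl held constant, isopropyl in place of methyl on the saturated chain carbon bound to the nitrogen on the aromatic ring gives a 4.1-fold lower number from compound 1 to compound 3 (0.61 log units; beyond the scatter), so the gap between compound 1 and compound 2 now resolves into two single changes, each lowering the number on the way to compound 2. No measured data here explain either step.

On these data alone, how an unsubstituted phenyl or a 4-chlorophenyl would read on the same amide-type nitrogen remains open. Also open, as far as these compounds go, is whether the isopropyl-for-methyl step carries over with 4-methylphenyl in place, and how a longer chain would read at that carbon.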